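Isopropyl to (tert-butyl)amino on a carbonyl carbon

A few compounds are considered here, and "the series" means these few. Any claim that something is new, unique, unknown or untested is made for them only; others in the source may bear on it.

In a physicochemical assay for solubility (on this read-out lower numbers stand for lower solubility and higher numbers for higher solubility), compound 2 (`CC(C)C(=O)N1CCC[C@H]1C(=O)N1CCC(NS(=O)(=O)c2cc(S(=O)(=O)c3ccccc3)ccc2C(F)(F)F)CC1`) gives 100000 nM. Compound 1 (`CC(C)(C)OC(=O)N1C(=O)CC[C@H]1C(=O)N1CCC(NS(=O)(=O)c2cc(S(=O)(=O)c3ccccc3)ccc2C(F)(F)F)CC1`) gives 50000 nM, a value within the scatter of that of compound 2. Compound 3 (`CC(C)(C)CC(=O)N1CCC[C@H]1C(=O)N1CCC(NS(=O)(=O)c2cc(S(=O)(=O)c3ccccc3)ccc2C(F)(F)F)CC1`) gives 25000 nM, which lies beyond the scatter from compound 2. Compound 2 therefore stands clear of compound 3 but not of compound 1.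

Compound 4 (`CC(C)(C)NC(=O)N1CCC[C@H]1C(=O)N1CCC(NS(=O)(=O)c2cc(S(=O)(=O)c3ccccc3)ccc2C(F)(F)F)CC1`) arises from compound 2 by one change: (tert-butyl)amino in place of isopropyl on a carbonyl carbon. It has (tert-butyl)amino in place of isopropyl on a carbonyl carbon, so isopropylcarbonyl becomes (tert-butyl)carbamoyl.

Within the data shown here, only one measured step bears on this change: a 4.0-fold lower number from compound 2 to compound 3 (0.60 log units; beyond the scatter). This modest step has neopentyl in place of isopropyl on a carbonyl carbon. Among the measured compounds shown here, no measured compound carries the entering group, so the guidance is indirect. A step in the same direction but of smaller size is expected in this assay, estimated as a 2.5-fold lower number from compound 2 to compound 4 (0.40 log units; beyond the scatter). For compound 4 the estimated value is 40000 nM, with an expected range of 15000 nM to 100000 nM.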

Compound 4, solubility: 50000 nM
The estimate for compound 4 lay 1.3-fold (0.10 log units) below the measured number; measured number inside the range.
By their numbers in this assay, from the lowest: compounds 3, 1, 4 and 2 (each within the scatter of the next, the first and the last beyond it).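

Replacing isopropyl with (tert-butyl)amino on this carbonyl carbon gives a 2.0-fold lower number from compound 2 to compound 4 (0.30 log units; within the scatter) in this assay, so a nitrogen-linked group at this position is not separated from the isopropyl of compound 2 on this read-out. The neopentyl comparison gives a 2.0-fold higher number from compound 3 to compound 4 (0.30 log units; within the scatter), and compound 4 is therefore not separated from compound 3 either, even though the step of a 4.0-fold lower number from compound 2 to compound 3 (0.60 log units; beyond the scatter) lies beyond the scatter. The data on hand offer no explanation for these numbers.

As far as these compounds go, what a longer chain ending in a carboxylic acid, or a dimethylamino group, would give on this carbonyl carbon remains open. Also open, from the compounds shown here alone, is whether the (tert-butyl)amino result would hold with a different group elsewhere on the shared core.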